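The source may report more compounds than this note shows. Statements on the series, on what has been measured and on what is new or still open speak of the compounds shown alone.

Series notes. Compound 1 `Cc1nnc(SCc2ccccc2)n1N1C(=O)c2ccccc2C1=O`, compound 2 `CSc1nnc(C)n1N1C(=O)c2ccccc2C1=O` and compound 3 `COc1cc(-c2nnc(SC)n2N2C(=O)c3ccccc3C2=O)cc(OC)c1OC` have been run in a functional assay on HepG2 cells (Homo sapiens) for cytotoxicity, read by MTT assay, with a stated time of 48 h; a higher number here means a weaker inhibitor, a lower number a stronger inhibitor. For compound 1 the result is only a limit, > 200000 nM. For compound 2 the result is likewise a limit, > 200000 nM. For compound 3 the result is again a limit, > 200000 nM. Compound 2 and compound 1 differ by phenyl in place of hydrogen on a saturated chain carbon bound to a sulfur; the step that the two limits leave unreadable from compound 2 to compound 1 is not readable, as both values sit at the limit of > 200000 nM in this assay, at which 3 of the 3 values shown sit. How the core of compound 3 differs from the core of compound 2 is not broken down here. Compound 4 `COc1cc(-c2nnc(SCc3ccccc3)n2N2C(=O)c3ccccc3C2=O)cc(OC)c1OC` is still to be measured; it differs from compound 3 by phenyl in place of hydrogen on a saturated chain carbon bound to a sulfur, the same change at the same place. For compound 4 the step that the limit leaves unreadable from compound 3 to compound 4 is expected to be flat, because a step that the two limits leave unreadable from compound 2 to compound 1 is unreadable at the limit of > 200000 nM in this assay, at which 3 of the 3 values shown sit. Compound 4 is expected to give about 300000 nM, between 100000 nM and 1000000 nM, most probably again only a limit.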

Compound 4, half-maximal inhibitory concentration: > 200000 nM
Compound 4: only a limit was reported; the forecaster's own chance of this, stated with the estimate: 85%; the middle value does not contradict the limit.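

No new step can be read from compound 3 to compound 4 or from compound 1 to compound 4, as each value is only a limit: the limit of > 200000 nM in this assay, at which 4 of the 4 values shown sit. The compounds shown leave open whether either change has any effect in this assay.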